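The source may report more compounds than this note shows. Statements on the series, on what has been measured and on what is new or still open speak of the compounds shown alone.

Measured in a functional assay on HEK293 cells for agonist activity at 5-hydroxytryptamine receptor 3A (Homo sapiens), read by FLIPR; on this read-out lower numbers stand for stronger inhibition and higher numbers for weaker inhibition:
Compound 1 `O=C(NCCCCN1CCCCC1)Nc1ccc(-c2ccccc2)cc1` gives 7900 nM.
Compound 2 `O=C(NCCCCN1CCCCC1)Nc1ccc(-c2ccc(F)nc2)nc1` gives only the assay limit > 30000 nM.
Compound 3 `COc1ccccc1-c1ccc(NC(=O)NCCCCN2CCCCC2)cn1` gives only the assay limit > 30000 nM.

For the measured compounds named here, compound 1 holds the only number among the three; the other two values are limits, so compound 1 stands alone as the single readable point of the set. Going by the values given here, the one step between measured compounds that differ in a single place, a step that the two limits leave unreadable from compound 2 to compound 3, has both ends at the limit of > 30000 nM in this assay, at which 2 of the 3 values shown sit, and its size cannot be read.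

Compound 4 `COc1ccccc1-c1ccc(NC(=O)NCCCCN2CCCCC2)cc1` is not yet measured. It differs from compound 1 by methoxy in place of hydrogen on an aromatic carbon; cut one bond further out, the change reads phenyl to 2-methoxyphenyl, the methoxy sitting ortho to a large group. Among the compounds with values here, no measured step carries this change on the all-carbon ring of compound 1. The nearest comparison is compound 3, which carries 2-methoxyphenyl on a different core and sits at the limit; it gives no number to carry over, and compound 1 and compound 3 differ in more than one place. The step from compound 1 to compound 4 is expected to be a 1.5-fold higher number from compound 1 to compound 4 (0.18 log units; within the scatter) in this assay, with a real chance that only a limit is returned. Compound 4 is expected at 12000 nM, between 4000 nM and 40000 nM.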

Compound 4, half-maximal inhibitory concentration in the 5-hydroxytryptamine receptor 3A assay: 7800 nM
Compound 4: the middle estimate sits 1.5-fold (0.19 log units) above what was measured; measured number inside the range.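

In the 5-hydroxytryptamine receptor 3A assay compound 4 gives 7800 nM and so still returns a readable number, and the step (a 1.0-fold lower number from compound 1 to compound 4 (0.01 log units; within the scatter)) shows that methoxy in place of hydrogen on an aromatic carbon, ortho to a large group, is accepted on the core of compound 1. In a physicochemical assay for solubility, at pH 7.4 (a higher number here means a more soluble compound, a lower number a less soluble compound), compound 1 gives 108000 nM and compound 4 gives 114000 nM and the same change also stays within the scatter (a 1.1-fold higher number from compound 1 to compound 4 (0.02 log units; within the scatter)), so phenyl and 2-methoxyphenyl are not told apart on this core by either read-out. Compound 3, with 2-methoxyphenyl on another core, gave only an assay limit, which could say nothing about this group on the all-carbon ring, and nothing measured here bears on why the step is so small.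

As far as these compounds go, the step from compound 2 to compound 3 cannot be read, so how this exchange behaves on the core of those two compounds stays unknown. Also open, from the compounds shown here alone, is whether a different group at this place, such as an amine, a carboxylic acid or a longer alkoxy chain, would move the number on the core of compound 1 beyond the scatter.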